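The source may hold more compounds than are shown below. What is called first, only, known or untested is meant among the compounds shown, and "the series" means these compounds.

Within the data shown here, in an ADME assay on cells (Homo sapiens) for cytotoxicity, read by polymerase chain reaction, with a stated time of 3 days (a lower number here means that less compound is tolerated, a higher number that more compound is tolerated), only two compounds have numbers so far. Compound 1 `Cc1nc(NC(C)C)nc(N[C@@H]2C[C@H](CO)[C@@H](O)[C@H]2O)c1-c1nc2ccccc2s1` gives 13000 nM, and compound 2 `Cc1nc(NCc2cccs2)nc(N[C@@H]2C[C@H](CO)[C@@H](O)[C@H]2O)c1-c1nc2ccccc2s1` gives 6000 nM, the lower of the two. Compound 3 `Cc1nc(NCc2ccsc2)nc(N[C@@H]2C[C@H](CO)[C@@H](O)[C@H]2O)c1-c1nc2ccccc2s1` differs from compound 2 in a single detail: thiophen-3-yl in place of thiophen-2-yl on a saturated chain carbon bound to a nitrogen on an aromatic ring. The atoms stay the same, but the thiophene ring is joined to its saturated chain carbon through a different ring position.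

Among the measured compounds shown here, only one measured step bears on this change: a 2.2-fold lower number from compound 1 to compound 2 (0.34 log units; beyond the scatter), with (thiophen-2-yl)methyl in place of isopropyl. That step exchanged one whole group for another, and its size was still modest. The new change exchanges no atoms at all, so it should give a smaller step than that one. For the measured compounds named here, no measured pair shows what moving from thiophen-2-yl to thiophen-3-yl does in this assay, so the data suggest no direction. The expected result is a 1.1-fold higher number from compound 2 to compound 3 (0.03 log units; within the scatter), which would be no step beyond the scatter. For compound 3 the estimate is 6500 nM, with an expected range from 3000 nM to 14000 nM.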

Compound 3, half-maximal cytotoxic concentration: 6000 nM
Estimate against measurement, compound 3: 1.1-fold (0.03 log units) above; the measured number falls inside the stated range.
By their numbers in this assay, from the lowest: compounds 2 and 3 (each within the scatter of the next); then compound 1.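

In this assay, joining the thiophene ring to its saturated chain carbon through a different ring position gives no change at the digits printed from compound 2 to compound 3 (within the scatter) and so shows that, at this position, this change of attachment leaves the read-out where it was. The exchange of isopropyl also holds for the new group, with a 2.2-fold lower number from compound 1 to compound 3 (0.34 log units; beyond the scatter) matching the earlier step in size, so the gap from compound 1 does not depend on which of these two thiophene attachments is present. No measurement shown here explains either the unchanged number or the gap from isopropyl.

On these data alone, these three compounds cover only isopropyl and the two (thiophenyl)methyl groups on this nitrogen, so it remains open whether a benzyl group, with a six-membered ring in place of thiophene, or a furan-2-ylmethyl group would give a number close to that of compound 2. Also open, as far as these compounds go, is what a longer chain between the nitrogen and the thiophene ring would do, or whether a terminal amine or carboxylic acid on that chain would shift the number in either direction.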